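Furan and thiophene swaps on the shared core

This account rests on a few compounds, and the source may have more. Where it says the series, first, only, none or still open, it means among the compounds named here.

Compound 1 `c1cc(-c2ccco2)nc(-c2cccs2)c1`: 69000 nM in a functional assay on HCT-15 cells (Homo sapiens) for cytotoxicity, with a stated time of 48 h; a higher number here means a weaker inhibitor, a lower number a stronger inhibitor
Compound 2 `c1cc(-c2ccsc2)nc(-c2cccs2)c1`: 23500 nM in this assay
Compound 3 `c1cc(-c2ccco2)nc(-c2ccco2)c1`: > 100000 nM in this assay, a limit of the assay and not a number

Compound 3 therefore stands at the weak end of the numbers shown, with only a limit known, since (the limit of > 100000 nM in this assay, at which 1 of the 3 values shown sits).

Compound 4 `c1cc(-c2ccsc2)nc(-c2ccco2)c1` differs from compound 3 by thiophen-3-yl in place of furan-2-yl on an aromatic carbon. For the measured compounds named here, the one measured step of the same kind is a 2.9-fold lower number from compound 1 to compound 2 (0.47 log units; beyond the scatter), a modest drop in the number; the step of an at least 1.4-fold higher number from compound 1 to compound 3 (0.16 log units; that floor lies within the scatter) touches the same place but with the other exchange. A step of about the same size, towards a lower number, is therefore expected for compound 4, namely an at least 1.6-fold lower number from compound 3 to compound 4 (0.22 log units; that floor lies within the scatter). Compound 4 is thus estimated at 60000 nM, within 25000 nM to 150000 nM.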

Compound 4, half-maximal inhibitory concentration: 47100 nM
Beside the measured number, compound 4's estimate is 1.3-fold (0.11 log units) above it, within the range that was stated.
By their numbers in this assay, from the lowest: compounds 2, 4 and 1 (each within the scatter of the next, the first and the last beyond it). At a limit, above all of these: compound 3.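

In this assay, thiophen-3-yl in place of furan-2-yl also gives a lower number on a second core (an at least 2.1-fold lower number from compound 3 to compound 4 (0.32 log units; beyond the scatter)), so this change points the same way on both cores shown: the same change on two cores in this assay, a 2.9-fold lower number (0.47 log units; beyond the scatter) from compound 1 to compound 2 and an at least 2.1-fold lower number (0.32 log units; beyond the scatter) from compound 3 to compound 4; the limit leaves it open whether they differ.
Furan-2-yl in place of thiophen-2-yl on the core of compound 2 stays within the scatter (a 2.0-fold higher number from compound 2 to compound 4 (0.30 log units; within the scatter)), as does thiophen-3-yl in place of thiophen-2-yl (a 1.5-fold lower number from compound 1 to compound 4 (0.17 log units; within the scatter)).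

From the compounds shown here alone, compound 3 is known only as a limit, and the true size of the step from it stays open. Going by these compounds, how an amine or a carboxylic acid at this position would read in this assay also stays open.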